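A few compounds are considered here, and "the series" means these few. Any claim that something is new, unique, unknown or untested is made for them only; others in the source may bear on it.

Compound 1 `C/C(=C\CCc1ccoc1)CC/C=C(\C)CCC[C@@H](C)CC(=O)O` and compound 2 `CC1=C(O)/C(=C/[C@H](C)CCC/C(C)=C/CC/C(C)=C/CCc2ccoc2)OC1=O` share the long chain and differ in what ends it. In a functional assay on K562 cells (Homo sapiens) for cytotoxicity, read by MTT assay (a lower number here means that less compound is tolerated, a higher number that more compound is tolerated), compound 1 gives only a limit, > 100 ug/mL. In this assay compound 2 gives 39 ug/mL. Within the data shown here, the one measured step is an at least 2.5-fold lower number from compound 1 to compound 2 (0.40 log units; beyond the scatter). Among the measured compounds shown here, compound 2 therefore holds the only number in this assay; the other value shown is the limit of > 100 ug/mL in this assay, at which 1 of the 2 values shown sits.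

Compound 3 `COC1C=C(CC/C=C(\C)CC/C=C(\C)CCC[C@@H](C)/C=C2\OC(=O)C(C)=C2O)C(OC)O1` differs from compound 2 in the furan-3-yl: a group of 9 heavy atoms (6 carbon, 3 oxygen; one five-membered non-aromatic ring with 1 hetero atom) in place of a group of 5 heavy atoms (4 carbon, 1 oxygen; one five-membered aromatic ring with 1 hetero atom), on a saturated chain carbon, two bonds along the chain from a double-bonded chain carbon. For the measured compounds named here, no measured step touches this group; the single step measured, an at least 2.5-fold lower number from compound 1 to compound 2 (0.40 log units; beyond the scatter), concerned a different part of the molecule and gives no direction for this one. The step of a 1.1-fold lower number from compound 2 to compound 3 (0.05 log units; within the scatter) is therefore expected to stay within the scatter, with wide uncertainty. Compound 3 is estimated at 35 ug/mL, ranging from 12 ug/mL to 100 ug/mL.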

Compound 3, concentration lethal to 50% of the cells: 80 ug/mL
Compound 3: the middle estimate sits 2.3-fold (0.36 log units) below what was measured; the range from low to high includes it.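

This position is not silent in this assay: with the group of 9 heavy atoms in place of furan-3-yl, the result is a 2.1-fold higher number from compound 2 to compound 3 (0.31 log units; beyond the scatter). The direction is opposite to that of the step in a different part of the molecule, an at least 2.5-fold lower number from compound 1 to compound 2 (0.40 log units; beyond the scatter), so the number moves both ways within this short series, and more compound is tolerated once the furan-3-yl leaves. Nothing measured here gives a reason for the change at this position.

Open, as far as these compounds go, is which feature of the entering group carries the step, since the loss of the aromatic ring and the entry of the additional oxygen atoms happen together. A phenyl ring, a saturated tetrahydrofuran ring or a carboxylic acid at this place would help to separate these.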